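This account rests on a few compounds, and the source may have more. Where it says the series, first, only, none or still open, it means among the compounds named here.

For the measured compounds named here, in a functional assay on PC-3 cells (Homo sapiens) for antiproliferative activity, read by MTT assay, with a stated time of 24 h (on this read-out lower numbers stand for stronger inhibition and higher numbers for weaker inhibition), compound 2 (`CCn1c(C(=O)N[C@H](C)C(=O)O)ccc1C(CC)(CC)c1ccc(OCS(=O)(=O)c2ccccc2)c(C)c1`) gives 20100 nM, the higher of the two numbers so far, while compound 1 (`CCN(CC)CCNC(=O)c1ccc(C(CC)(CC)c2ccc(OCS(=O)(=O)c3ccccc3)c(C)c2)n1CC`) gives 7130 nM. Compound 3 (`CCn1c(C(=O)N[C@H](CC(=O)O)C(=O)O)ccc1C(CC)(CC)c1ccc(OCS(=O)(=O)c2ccccc2)c(C)c1`) differs from compound 2 by carboxy in place of hydrogen on a saturated chain carbon, two bonds along the chain from an amide-type nitrogen and a carbonyl carbon: carboxy in place of hydrogen on a saturated chain carbon. Going by the values given here, only one measured step bears on this, a 2.8-fold higher number from compound 1 to compound 2 (0.45 log units; beyond the scatter), where 1-carboxyethyl replaces 2-(diethylamino)ethyl on an amide-type nitrogen. In this assay a small upward step, within the scatter, is expected, estimated as a 1.3-fold higher number from compound 2 to compound 3 (0.11 log units; within the scatter). Compound 3 is estimated at 26000 nM, with an expected range from 10000 nM to 65000 nM.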

Compound 3, half-maximal inhibitory concentration: > 50000 nM
Compound 3 ended at the assay's limit (the forecaster's own chance of this, stated with the estimate: 12%); middle value at least 1.9-fold (0.28 log units) away from the limit.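

In this assay compound 3 gives > 50000 nM, which is a limit of the assay and not a number. Carboxy in place of hydrogen on this saturated chain carbon gives an at least 2.4-fold higher number from compound 2 to compound 3 (0.39 log units; beyond the scatter), so the position responds to this change, and in the direction of weaker inhibition. 1,2-Dicarboxyethyl in place of 2-(diethylamino)ethyl on the amide-type nitrogen gives an at least 7.0-fold higher number from compound 1 to compound 3 (0.84 log units; beyond the scatter), a wider span than compound 2 alone showed.

On these data alone, the true size of both steps remains open, as compound 3 reads only as a limit. Also open, as far as these compounds go, is whether a methyl ester of this carboxy group or a hydroxymethyl group at the same carbon would give a readable number.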